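A few compounds are considered here, and "the series" means these few. Any claim that something is new, unique, unknown or untested is made for them only; others in the source may bear on it.

Measured compounds in an assay on membranes from brain for inhibition of Fatty-acid amide hydrolase 1 (Rattus norvegicus); on this read-out lower numbers stand for stronger inhibition and higher numbers for weaker inhibition:

- compound 1, `CCCCCCCCCCC[C@@H](C[C@@H]1OC(=O)[C@H]1CCCCCC)OC(=O)CCC(C)C`: compound 1 gives 10400 nM
- compound 2, `CCCCCCCCCCC[C@@H](C[C@@H]1OC(=O)[C@H]1CCCCCC)OC(=O)CNC(=O)OCc1ccccc1`: compound 2 gives only a limit, > 50000 nM
- compound 3, `CCCCCCCCCCC[C@@H](C[C@@H]1OC(=O)[C@H]1CCCCCC)OC(=O)[C@H](C)NC=O`: compound 3 gives only a limit, > 50000 nM

Compound 3 stands at the upper end of what has been resolved: its value in this assay is a limit, not a number, and it shares that standing with compound 2, as the limit of > 50000 nM in this assay, at which 2 of the 3 values shown sit, records. Going by the values given here, compound 1 is the one compound of the three with a measured number.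

Compound 4, `CCCCCCCCCCC[C@@H](C[C@@H]1OC(=O)[C@H]1CCCCCC)OC(=O)CCNC=O`, is not yet measured. It differs from compound 3 by a group of 5 heavy atoms (3 carbon, 1 nitrogen, 1 oxygen; no ring) in place of a group of 5 heavy atoms (3 carbon, 1 nitrogen, 1 oxygen; no ring), on a carbonyl carbon.

Among the compounds with values here, the steps that bear on this change are an at least 4.8-fold higher number from compound 1 to compound 3 (0.68 log units; beyond the scatter) and a step that the two limits leave unreadable from compound 2 to compound 3. Within the data shown here, the first shows that a group of this kind on the carbonyl carbon carries the series past the limit; the second cannot be sized. Nothing here separates the two arrangements of the same atoms, so no step beyond the scatter is expected between compound 3 and compound 4, and a further limit is the likely outcome.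

Compound 4 is therefore expected to give about 70000 nM in this assay, within 25000 nM to 200000 nM, which means an expected step that the limit leaves unreadable from compound 3 to compound 4.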

Compound 4, half-maximal inhibitory concentration: > 50000 nM
Compound 4: no number, only a limit; the forecaster's own chance of this, stated with the estimate: 70%; the middle value does not contradict the limit.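

The 2-(formylamino)ethyl group on this carbonyl carbon gives an at least 4.8-fold higher number from compound 1 to compound 4 (0.68 log units; beyond the scatter), so a formylamino-bearing group at this position reaches the limit in this assay even without the defined stereocentre of the group in compound 3. Going by these compounds alone, compound 1 is now the only compound that goes against the nitrogen-bearing groups here, and the series gathers at a single limit: the limit of > 50000 nM in this assay, at which 3 of the 4 values shown sit. The steps between compounds 2, 3 and 4 cannot be read, since both ends of each are limits, and the two arrangements of the same atoms therefore cannot be ordered.

On these data alone, how far compounds 2, 3 and 4 lie past the limit remains open. Also open, as far as these compounds go, is whether a free amine or a longer alkyl chain on this carbonyl carbon would give a number, as compound 1 does, or another limit.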